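The source may hold more compounds than are shown below. What is called first, only, known or untested is meant among the compounds shown, and "the series" means these compounds.

Measured so far:

- compound 1 `Cc1[nH]c2ccc([N+](=O)[O-])cc2c1C1(c2c(C)[nH]c3ccc([N+](=O)[O-])cc23)C(=O)Nc2ccccc21`: 99400 nM
- compound 2 `COC(=O)c1ccc2[nH]cc(C3(c4c[nH]c5ccc(C(=O)OC)cc45)C(=O)Nc4ccccc43)c2c1`: > 100000 nM, a limit of the assay rather than a number
- compound 3 `Cc1[nH]c2ccc([N+](=O)[O-])cc2c1C1(c2c(C)[nH]c3ccc([N+](=O)[O-])cc23)C(=O)Nc2ccc(Cl)cc21`: 10100 nM

All three were tested in a functional assay on MDA-MB-231 cells (Homo sapiens) for cytotoxicity, read by MTT assay, with a stated time of 48 h; on this read-out lower numbers stand for stronger inhibition and higher numbers for weaker inhibition. Compound 1 and compound 3 share one core, and the step between them is a single change: chloro in place of hydrogen on an aromatic carbon. That change produced a 9.8-fold lower number from compound 1 to compound 3 (0.99 log units; beyond the scatter). Compound 2 is built on a different core; the difference between the two cores is not broken down here. Compound 2 gave no number in this assay, only a limit, and this is the limit of > 100000 nM in this assay, at which 1 of the 3 values shown sits.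

Compound 4 `COC(=O)c1ccc2[nH]cc(C3(c4c[nH]c5ccc(C(=O)OC)cc45)C(=O)Nc4ccc(Cl)cc43)c2c1` is not yet measured. It stands to compound 2 exactly as compound 3 stands to compound 1: chloro in place of hydrogen on an aromatic carbon. The place of the change is described in the same words for both pairs, so the change is the same one, made on a different core.

Among the compounds with values here, the only measured instance of this change, from compound 1 to compound 3, lowered the number by a modest amount. Whether it does the same on the core of compound 2 cannot be read from one example, and the starting point for compound 2 is a limit, not a number, so the size of the step from compound 2 to compound 4 is uncertain in both directions. Within the data shown here, still, in this assay the expectation for compound 4 is 40000 nM, with a range from 10000 nM to 150000 nM, which means an expected step of an at least 2.5-fold lower number from compound 2 to compound 4 (0.39 log units; beyond the scatter), resting on a 9.8-fold lower number from compound 1 to compound 3 (0.99 log units; beyond the scatter) as the sole precedent and on the limit of compound 2 as the starting point.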

Compound 4, half-maximal inhibitory concentration: 10000 nM
Compound 4: middle estimate off by 4.0-fold (0.60 log units), on the high side, and the stated range covers the measured number.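

In this assay, chloro in place of hydrogen on an aromatic carbon gave an at least 10-fold lower number from compound 2 to compound 4 (1.00 log units; beyond the scatter), so the change lowered the number on the core of compound 2 as it had on the core of compound 1. Within the data shown here, this shows that the direction of the change carried over from one core to the other, but two cores are only two examples and make no rule for the whole series, and whether the size of the step carried over as well stays unsettled: the same change on two cores in this assay, a 9.8-fold lower number (0.99 log units; beyond the scatter) from compound 1 to compound 3 and an at least 10-fold lower number (1.00 log units; beyond the scatter) from compound 2 to compound 4; the limit leaves it open whether they differ Compound 2 stands at > 100000 nM, which is a limit of the assay and not a number.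

The compounds shown leave open whether another group on the same aromatic carbon, such as fluoro, bromo, methoxy or an amine, would lower the number as chloro does, and whether chloro would do the same on another carbon of that ring. They also leave open whether the step would hold on a further core, for example one carrying a carboxylic acid where compound 2 and compound 4 carry their methyl esters.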